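The source may report more compounds than this note shows. Statements on the series, on what has been measured and on what is new or still open speak of the compounds shown alone.

Of the compounds shown here, two sharing one core have been measured so far in a functional assay on DU-145 cells (Homo sapiens) for inhibition, read by trypan blue exclusion, with a stated time of 96 h (a higher number here means a weaker inhibitor of growth, a lower number a stronger inhibitor of growth), as growth inhibitors. Compound 1 `O=C(/C(=C\c1ccc(F)cc1C(F)(F)F)SCc1ccc(F)cc1)c1ccc(Br)cc1` gives 10000 nM as its number, while compound 2 `COc1ccc(/C=C(/SCc2ccc(F)cc2)C(=O)c2ccc(Br)cc2)cc1O` gives 1000 nM as the lower of the two, a gap beyond the usual scatter. Compound 3 `Cc1cc(F)ccc1/C=C(/SCc1ccc(F)cc1)C(=O)c1ccc(Br)cc1` has not yet been measured. It carries 4-fluoro-2-methylphenyl in place of the 3-hydroxy-4-methoxyphenyl of compound 2 on a double-bonded chain carbon bound to a double-bonded chain carbon (4-fluoro-2-methylphenyl in place of 3-hydroxy-4-methoxyphenyl on a double-bonded chain carbon bound to a double-bonded chain carbon). Compound 1 also lacks 3-hydroxy-4-methoxyphenyl and gives 10000 nM as its number, so compound 3 is expected to be a weaker inhibitor of growth than compound 2. The estimated change is a rise beyond the scatter, a 4.0-fold higher number from compound 2 to compound 3 (0.60 log units; beyond the scatter) in size. Compound 3 is expected at 4000 nM in this assay with 1500 nM to 10000 nM as the estimated range.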

Compound 3, concentration for 50% growth inhibition: 10000 nM
The estimate for compound 3 lay 2.5-fold (0.40 log units) below the measured number; low and high end bracket the measured number.
By their numbers in this assay, from the lowest: compound 2; then compounds 1 and 3 (each within the scatter of the next).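

In this assay, going by these compounds alone, the exchange of 3-hydroxy-4-methoxyphenyl for 4-fluoro-2-methylphenyl on a double-bonded chain carbon bound to a double-bonded chain carbon gives a 10-fold higher number from compound 2 to compound 3 (1.00 log units; beyond the scatter) and provides the first single-place comparison at this position. Methyl in place of trifluoromethyl on an aromatic carbon gives no change at the digits printed from compound 1 to compound 3 (within the scatter) and so separates compound 1 and compound 3 by nothing beyond the scatter, which leaves compound 2 with the only lower number of the three. The data shown offer no explanation for the difference between these rings.

Going by these compounds, whether the hydroxyl, the methoxy or the two together accompany the lower number remains open, since no ring here carries just one of them. An amine in place of the hydroxyl would be a further open case at this position.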